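The source may report more compounds than this note shows. Statements on the series, on what has been measured and on what is new or still open speak of the compounds shown alone.

Compound 1 `CCn1c(C(=O)NCCN(C)C)ccc1C(CC)(CC)c1ccc(OCC(=O)C(C)(C)C)c(C)c1` gives 2500 nM in an ADME assay on L02 cells (Homo sapiens) for cytotoxicity, read by MTT assay, with a stated time of 48 h; a lower number here means a stronger inhibitor, a higher number a weaker inhibitor. Two companions differ from it only at the amine end of the amide side chain: compound 2 `CCN(CC)CCCNC(=O)c1ccc(C(CC)(CC)c2ccc(OCC(=O)C(C)(C)C)c(C)c2)n1CC`, which gives 2300 nM, and compound 3 `CCn1c(C(=O)NCCN)ccc1C(CC)(CC)c1ccc(OCC(=O)C(C)(C)C)c(C)c1`, which gives 2500 nM. The step of a 1.1-fold lower number from compound 1 to compound 2 (0.04 log units; within the scatter) and the step of no change at the digits printed from compound 1 to compound 3 (within the scatter) both stay within the scatter, so compound 1 sits level with the other two.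

Compound 4 `CCn1c(C(=O)NCCN(C)C)ccc1C(CC)(CC)c1ccc(OCC(O)C(C)(C)C)c(C)c1` is reached from compound 1 by a change elsewhere: 1-hydroxy-2,2-dimethylpropyl in place of (tert-butyl)carbonyl on a saturated chain carbon bound to an oxygen on an aromatic ring. Among the measured compounds shown here, no measured step touches that part of the molecule; the three steps known all concern the amine on the amide side chain. There is thus no basis for expecting a shift beyond the scatter, and the step of no change at the digits printed from compound 1 to compound 4 (within the scatter) is estimated as flat. Compound 4 is expected to give about 2500 nM, within 1200 nM to 5200 nM.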

Compound 4, half-maximal inhibitory concentration: 2600 nM
For compound 4 the middle estimate is 1.0-fold (0.02 log units) below the measured one, within the range that was stated.
By their numbers in this assay, from the lowest: compounds 2, 1, 3 and 4 (each within the scatter of the next).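

The first change away from the amine end of the amide side chain, 1-hydroxy-2,2-dimethylpropyl in place of (tert-butyl)carbonyl, gives a 1.0-fold higher number from compound 1 to compound 4 (0.02 log units; within the scatter) in this assay. This position therefore takes a change that adds a hydrogen-bond donor and loses the carbonyl without a step beyond the scatter. Nothing available explains this result. Still open, as far as these compounds go, is whether an amine or a carboxylic acid in place of the (tert-butyl)carbonyl would also stay level with compound 1.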